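Side-Chain Swap on a Shared Core

A few compounds are considered here, and "the series" means these few. Any claim that something is new, unique, unknown or untested is made for them only; others in the source may bear on it.

Measured compounds:
compound 1 `O=C1c2c[n+]([O-])c3ccccc3c2C(=O)c2c1c1ccccc1n2CCCCN1CCNCC1`: 3310 nM
compound 2 `CC1(C)O[C@@H](CO)[C@H](Cn2cc(Cn3c4c(c5ccccc53)C(=O)c3c[n+]([O-])c5ccccc5c3C4=O)nn2)O1`: 680 nM
compound 3 `CC1(C)OC[C@H](Cn2cc(Cn3c4c(c5ccccc53)C(=O)c3c[n+]([O-])c5ccccc5c3C4=O)nn2)O1`: 530 nM

In a functional assay on MDA-MB-231 cells (Homo sapiens) for cytotoxicity, read by MTT assay, with a stated time of 72 h (on this read-out lower numbers stand for stronger inhibition and higher numbers for weaker inhibition), compound 1 gives 3310 nM, the highest number of the three, beyond the scatter from both compound 2 and compound 3. Compound 4 `O=C1c2c[n+]([O-])c3ccccc3c2C(=O)c2c1c1ccccc1n2CCCN1CCC(O)CC1` differs from compound 1 by 4-hydroxypiperidin-1-yl in place of (piperazin-1-yl)methyl on a saturated chain carbon, three bonds along the chain from an aromatic nitrogen. Among the compounds with values here, no measured step bears directly on this change. Within the data shown here, the only step in hand, a 1.3-fold lower number from compound 2 to compound 3 (0.11 log units; within the scatter), concerns a substituent on a saturated ring carbon and stays within the scatter, so it offers little guidance. With nothing in the data pointing in either direction, compound 4 is expected to show no step beyond the scatter, a 1.1-fold lower number from compound 1 to compound 4 (0.04 log units; within the scatter). The estimate for compound 4 in this assay is 3000 nM, with a range from 1000 nM to 9000 nM.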

Compound 4, half-maximal inhibitory concentration: 280 nM
Compound 4: middle estimate off by 11-fold (1.03 log units), on the high side; the whole stated range lies above it.
By their numbers in this assay, from the lowest: compounds 4, 3 and 2 (each within the scatter of the next, the first and the last beyond it); then compound 1.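

In this assay, within the data shown here, this position proves sensitive to the side chain: going from 4-(piperazin-1-yl)butyl to 3-(4-hydroxypiperidin-1-yl)propyl gives a 12-fold lower number from compound 1 to compound 4 (1.07 log units; beyond the scatter), a large step, whereas the only earlier step stayed within the scatter. The groups that leave and enter match in heavy atoms, donors, acceptors and net charge, so these counts do not follow the change. Nothing measured here explains the step. Going by these compounds, the ring and the chain length change together, so their shares remain open. A 3-(piperazin-1-yl)propyl or 4-(4-hydroxypiperidin-1-yl)butyl group on the shared core would separate them.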